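The source may report more compounds than this note shows. Statements on the series, on what has been measured and on what is new or still open speak of the compounds shown alone.

Three compounds have been measured in a functional assay on DLD-1 cells (Homo sapiens) for cytotoxicity, read by MTT assay, with a stated time of 48 h; a higher number here means a weaker inhibitor, a lower number a stronger inhibitor:

Compound 1 `CN(C)CCNc1ccnc2cc(OCc3ccccc3)ccc12`: 2140 nM
Compound 2 `Clc1ccnc2cc(OCc3ccccc3)ccc12`: 3270 nM
Compound 3 `CN(C)CCCNc1ccnc2cc(OCc3ccc(F)cc3)ccc12`: 2540 nM

Compound 1 gives the lowest of these three numbers, but its neighbours sit close: compound 3 is nearest, and compound 2 is furthest, and both gaps fall within the scatter, so no ordering among the three can be claimed. Among the measured compounds shown here, the only single-point step available, a 1.5-fold higher number from compound 1 to compound 2 (0.18 log units; within the scatter), changes the group on the aromatic carbon of the core and also stays within the scatter.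

Compound 4 `CCOc1ccc2c(NCCN(C)C)ccnc2c1` is the next compound for this assay. It differs from compound 1 at a different place: methyl in place of phenyl on a saturated chain carbon bound to an oxygen on an aromatic ring. For the measured compounds named here, none of the measured steps touches this part of the molecule; the step from compound 1 to compound 2 concerns the other end of the core, and compounds 1 and 3 differ in two places at once, so their values say only that both lie near each other. Going by the values given here, there is thus no measured precedent for the move from benzyloxy to ethoxy. In the absence of one, compound 4 is expected to land near compound 1, with the step of a 1.4-fold higher number from compound 1 to compound 4 (0.15 log units; within the scatter) most likely inside the scatter, although a wider range is allowed. The estimate for compound 4 is therefore 3000 nM, with a range from 1200 nM to 8000 nM.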

Compound 4, half-maximal inhibitory concentration: 6240 nM
For compound 4 the middle estimate is 2.1-fold (0.32 log units) below the measured one; low and high end bracket the measured number.
By their numbers in this assay, from the lowest: compounds 1, 3, 2 and 4 (each within the scatter of the next, the first and the last beyond it).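

In this assay, among the compounds shown here, the change from benzyloxy to ethoxy gives a 2.9-fold higher number from compound 1 to compound 4 (0.46 log units; beyond the scatter) and so becomes the first step here to lie beyond the scatter, whereas a 1.5-fold higher number from compound 1 to compound 2 (0.18 log units; within the scatter) stayed within it. Replacing phenyl with methyl on a saturated chain carbon bound to an oxygen on an aromatic ring therefore moves the number towards weaker inhibition, which shows that the result is sensitive to this part of the molecule, although the step is modest and rests on this single pair. No evidence at hand accounts for the size or direction of this step.

The compounds shown leave open whether a hydroxyl, a methoxy or a longer chain such as propoxy at this place would give a number closer to that of compound 1 or to that of compound 4, and whether a phenethyloxy group would do the same. They also leave open whether the same step would appear with the chloro group of compound 2 in place of the (2-(dimethylamino)ethyl)amino group.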